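A few compounds are considered here, and "the series" means these few. Any claim that something is new, unique, unknown or untested is made for them only; others in the source may bear on it.

Measured so far in an ADME assay on HCT-116 cells (Homo sapiens) for cytotoxicity, read by CellTiter-Glo, with a stated time of 72 h; a lower number here means a stronger inhibitor, a higher number a weaker inhibitor:

compound 1 `Cc1noc(C)c1S(=O)(=O)N1CCC(N2CCC(C)CC2)CC1` — > 10000 nM
compound 2 `Cc1cc(C)c(S(=O)(=O)N2CCC(N3CCC(c4ccccc4)CC3)CC2)c(C)c1` — > 5000 nM

Both entries are limits of the assay rather than numbers. Compound 1 stands at a limit, (the limit of > 10000 nM in this assay, at which 1 of the 2 values shown sits). Compound 2 likewise sits at a limit, (the limit of > 5000 nM in this assay, at which 1 of the 2 values shown sits). Within the data shown here, no step between the two measured compounds can be counted, since neither value is a number; the two values show only that neither compound reaches measurable inhibition within the range tested, and nothing on order or size between them can be said.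

Compound 3 `Cc1cccc(S(=O)(=O)N2CCC(N3CCC(C)CC3)CC2)c1` is not yet measured. It differs from compound 1 in one place, (3-methylphenyl in place of 3,5-dimethyl-1,2-oxazol-4-yl on a sulfonyl sulfur). Among the measured compounds shown here, no measured step of this kind exists, so the size of the change in this assay cannot be read from what is here. The step from compound 1 to compound 3 is expected to be none beyond the scatter, a step that the limit leaves unreadable from compound 1 to compound 3. Compound 3 is estimated at 15000 nM, with a range from 5000 nM to 50000 nM, and it is expected that the assay again reports only a limit rather than a number.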

Compound 3, half-maximal inhibitory concentration: > 5000 nM
Compound 3 ended at the assay's limit; the forecaster's own chance of this, stated with the estimate: 80%; the middle value lies beyond the limit too.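

Compound 1 and compound 3 both sit at limits of this assay, so the step between them, 3-methylphenyl in place of 3,5-dimethyl-1,2-oxazol-4-yl on a sulfonyl sulfur, cannot be read. On these data alone, whether this change alters inhibition at all, and in which direction, stays open, as neither compound has a numerical value.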